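Adding Pyridin-2-yl to the Bridge: Compound 2 to Compound 4

A few compounds are considered here, and "the series" means these few. Any claim that something is new, unique, unknown or untested is made for them only; others in the source may bear on it.

Measured so far:
compound 1, `C=CCc1cc(-c2ccc(O)c(CC=C)c2)ccc1O`, 45%
compound 2, `C=CCc1cc(Cc2ccc(O)c(CC=C)c2)ccc1O`, 75%
compound 3, `C=CCc1cc(C(=C(Cl)Cl)c2ccc(O)c(CC=C)c2)ccc1O`, 54%

In a functional assay on SVR cells (Mus musculus) for antiproliferative activity, with a stated time of 72 h, tested at 10 ug/mL (a lower number here means a weaker effect, a higher number a stronger effect of the compound at the concentration tested), compound 2 gives 75%, the highest of the three numbers; compound 3 lies lower by a gap beyond the scatter, and compound 1 lies lowest, also beyond the scatter. Compound 4, `C=CCc1cc(C(c2ccc(O)c(CC=C)c2)c2ccccn2)ccc1O`, has not been measured. It differs from compound 2 by pyridin-2-yl in place of hydrogen on a saturated chain carbon bound to two aromatic carbons. Among the measured compounds shown here, no two measured compounds differ in one place only, so the size of this step is not known from the data; compound 3 merely gives a lower number than compound 2. In this assay the step is expected to be downward by a moderate amount, a number 15 percentage points lower from compound 2 to compound 4 (beyond the scatter). Compound 4 is estimated to give 60%, within 40% to 80%.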

Compound 4, a percentage reported as inhibition, at one concentration (the size of the read-out at that concentration, not a potency): 25%
Estimate against measurement, compound 4: 35 percentage points above, and the stated range ends above it.
By their numbers in this assay, from the lowest: compound 4; then compounds 1 and 3 (each within the scatter of the next); then compound 2.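

In this assay, among the compounds shown here, pyridin-2-yl in place of hydrogen on a saturated chain carbon bound to two aromatic carbons gives a number 50 percentage points lower from compound 2 to compound 4 (beyond the scatter), the only step so far that changes one place alone. For the compounds shown here, it shows that this carbon does not accept every group without loss, which the earlier compounds could not show. Nothing measured here gives a reason for the drop.

From the compounds shown here alone, whether a methyl group, a phenyl ring or an amine on this carbon would bring a similar drop remains open. So does whether the drop follows from the ring itself or from its nitrogen.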